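Swapping the bicyclic amine on the aromatic carbon of compound 1

This account rests on a few compounds, and the source may have more. Where it says the series, first, only, none or still open, it means among the compounds named here.

Measured so far:
- compound 1, `CN(C[C@H]1Cc2c(cccc2N2C[C@@H]3C[C@H]2CN3)CN1)[C@H]1CCCc2cccnc21`, with 100%
- compound 2, `Cc1cnc2c(c1)CCC[C@@H]2N(C)C[C@H]1Cc2c(cccc2N2CCNCC2)CN1`, with 47.8%

In an ADME assay on microsomes from liver (Homo sapiens) for metabolic stability, read by LC-MS, with a stated time of 10 min (a higher number here means that more of the compound is left, a lower number that less of the compound is left), compound 1 gives 100%, the higher of the two numbers, while compound 2 gives 47.8%, a gap beyond the scatter. Compound 2 differs from compound 1 in more than one place, so no single step can be read from this pair; their two values only show that compound 1 stands higher.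

Compound 3, `CN(C[C@H]1Cc2c(cccc2N2CCN3CCC[C@H]3C2)CN1)[C@H]1CCCc2cccnc21`, is not yet measured. It differs from compound 1 in one place: a group of 9 heavy atoms (7 carbon, 2 nitrogen; one five-membered non-aromatic ring with 1 hetero atom, one six-membered non-aromatic ring with 2 hetero atoms) in place of a group of 7 heavy atoms (5 carbon, 2 nitrogen; 2 five-membered non-aromatic rings with 1 hetero atom each), on an aromatic carbon. The entering group keeps both of its hydrogen-bond acceptors but carries no hydrogen-bond donor, and it has one defined stereocentre where the leaving group had two.

Compound 1 sits at the top of the scale, so compound 3 cannot be expected to move upward; a moderate downward step from compound 1 to compound 3 of a number 25 percentage points lower from compound 1 to compound 3 (beyond the scatter) is expected, with the chance that the change stays within the scatter. For compound 3 the estimate is 75%, in a range from 45% to 100%.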

Compound 3, percent of the compound remaining: 36.6%
For compound 3 the middle estimate is 38.4 percentage points above the measured one, and the stated range ends above it.
By their numbers in this assay, from the lowest: compound 3; then compound 2; then compound 1.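

In this assay, among the compounds shown here, the single change on the aromatic carbon gives a number 63.4 percentage points lower from compound 1 to compound 3 (beyond the scatter) and so shows, for the first time, that this position matters: with the rest of compound 1 held constant, the group attached there can greatly alter how much compound remains. The step changes several features together, replacing two five-membered non-aromatic rings with one five-membered and one six-membered non-aromatic ring, going from 7 to 9 heavy atoms, from 1 hydrogen-bond donor to 0, and from 2 defined stereocentres to 1. No measurement shown here links the fall to any one of these features.

From the compounds shown here alone, it therefore remains open whether the fall follows the lost hydrogen-bond donor, the extra heavy atoms or the new ring arrangement. The bicyclic amine of compound 1 carrying a methyl group on its ring nitrogen would isolate the loss of the donor, while a morpholine at the same aromatic carbon of the shared core would offer a different ring with no such donor.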